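The compounds below may be only part of what the source reports. "The series", "measured", "known", "first", "only" and "open" are said of these compounds alone.

Measured so far in an ADME assay on a cell-free system (plasma, Homo sapiens) for metabolic stability, with Plasma (Rattus norvegicus) as the target, read by HPLC, at pH 7.4; a higher number here means that the compound lasts longer, a lower number that the compound disappears faster:
- compound 1 `CC(=O)Oc1ccccc1C(=O)O[C@H]1CO[C@H]2[C@@H]1OC[C@H]2OC(=O)c1snnc1C`: 0.0642 h
- compound 2 `CC(=O)Oc1ccccc1C(=O)O[C@H]1CO[C@H]2[C@@H]1OC[C@H]2OC(=O)c1ccnn1C`: 0.0963 h
- compound 3 `CC(=O)Oc1ccccc1C(=O)O[C@H]1CO[C@H]2[C@@H]1OC[C@H]2OC(C)=O`: 0.0608 h

All three compounds share the same core and the same acetylsalicyloyl ester; they differ only in the acyl group on the second ester. Compound 2 is the starting point here. The step of a 1.5-fold higher number from compound 1 to compound 2 (0.18 log units; within the scatter) and the step of a 1.6-fold lower number from compound 2 to compound 3 (0.20 log units; within the scatter) are both within the scatter, as is a 1.1-fold lower number from compound 1 to compound 3 (0.02 log units; within the scatter), so compound 2 cannot be set apart from the other two on these numbers; the whole set sits at short half-life.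

Compound 4 `CCCCC(=O)O[C@@H]1CO[C@H]2[C@@H]1OC[C@@H]2OC(=O)c1ccccc1OC(C)=O` is not yet measured. It differs from compound 2 as follows: butyl in place of 1-methyl-1H-pyrazol-5-yl on a carbonyl carbon. The closest measured step is the exchange of the same ring for a methyl on that carbonyl carbon, a 1.6-fold lower number from compound 2 to compound 3 (0.20 log units; within the scatter), which stayed within the scatter, and the exchange against a different five-membered ring, a 1.5-fold higher number from compound 1 to compound 2 (0.18 log units; within the scatter), likewise. For the measured compounds named here, no measured step here moves the number beyond the scatter, so for compound 4 no change beyond the scatter in this assay is expected: a 1.4-fold lower number from compound 2 to compound 4 (0.14 log units; within the scatter). The value of compound 4 is estimated at 0.07 h, in the range 0.035 h to 0.14 h.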

Compound 4, half-life: 0.0198 h
Estimate against measurement, compound 4: 3.5-fold (0.55 log units) above, outside the stated range (below it).
By their numbers in this assay, from the lowest: compound 4; then compounds 3, 1 and 2 (each within the scatter of the next).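

In this assay this position does respond to the acyl group: butyl gives a 4.9-fold lower number from compound 2 to compound 4 (0.69 log units; beyond the scatter) and a 3.2-fold lower number from compound 1 to compound 4 (0.51 log units; beyond the scatter) while the exchange on the methyl ester gives a 3.1-fold lower number from compound 3 to compound 4 (0.49 log units; beyond the scatter) and so sets compound 4 apart from the other three compounds. Losing the ring alone does not go with this drop, since compound 3 also carries no ring on this carbonyl carbon yet stays within the scatter of compound 1 and compound 2, so among these compounds the drop appears only with the butyl chain. Nothing available explains this drop.

Going by these compounds, whether an ethyl or propyl chain already gives part of the drop, and whether a longer chain such as hexyl goes further, stays open. So does the outcome with a branched tert-butyl group or a phenyl ring on this carbonyl carbon.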